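A few compounds are considered here, and "the series" means these few. Any claim that something is new, unique, unknown or untested is made for them only; others in the source may bear on it.

Of the compounds shown here, three built on one shared core have been measured in a functional assay on MCF7 cells (Homo sapiens) for antiproliferative activity, read by MTT assay, with a stated time of 96 h; a higher number here means a weaker inhibitor, a lower number a stronger inhibitor. Compound 1 `CCCc1ccc(N2C(=O)NC3(CSC4=C3C(=O)c3ncccc3C4=O)C2=O)cc1` gives 2 nM. Compound 2 `COc1ccc(N2C(=O)NC3(CSC4=C3C(=O)c3ncccc3C4=O)C2=O)cc1`, which carries methoxy in place of propyl on an aromatic carbon, gives 50 nM, which is a 25-fold higher number from compound 1 to compound 2 (1.40 log units; beyond the scatter). Compound 3 `O=C1C2=C(C(=O)c3ncccc31)C1(CS2)NC(=O)N(c2ccc([N+](=O)[O-])cc2)C1=O`, which carries nitro in place of propyl on that aromatic carbon, gives 350 nM. Compound 3 therefore stands with the highest number of the three: both a 180-fold higher number from compound 1 to compound 3 (2.24 log units; beyond the scatter) and a 7.0-fold higher number from compound 2 to compound 3 (0.85 log units; beyond the scatter) lie beyond the scatter, so compound 3 is the weakest inhibitor measured so far.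

Compound 4 `CCN(CC)c1ccc(N2C(=O)NC3(CSC4=C3C(=O)c3ncccc3C4=O)C2=O)cc1` has not yet been measured. It differs from compound 3 in one place: diethylamino in place of nitro on an aromatic carbon. For the measured compounds named here, two measured steps bear on this change, each ending at compound 3 with nitro on the aromatic carbon in question: a 180-fold higher number from compound 1 to compound 3 (2.24 log units; beyond the scatter) was large, and a 7.0-fold higher number from compound 2 to compound 3 (0.85 log units; beyond the scatter) was modest. Both groups seen in place of the nitro have gone with a clearly lower number in this assay, so a large step downward is expected for compound 4, of the order of a 44-fold lower number from compound 3 to compound 4 (1.64 log units; beyond the scatter). Compound 4 is accordingly estimated at 8 nM, within a range from 1.5 nM to 60 nM.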

Compound 4, half-maximal inhibitory concentration: 30 nM
Compound 4: the middle estimate sits 3.8-fold (0.57 log units) below what was measured, and the stated range covers the measured number.
By their numbers in this assay, from the lowest: compound 1; then compounds 4 and 2 (each within the scatter of the next); then compound 3.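

In this assay, diethylamino at this aromatic carbon, which sits para to a large group, brings a large drop from the number carried by nitro (a 12-fold lower number from compound 3 to compound 4 (1.07 log units; beyond the scatter)), so nitro now stands apart from all three other groups seen there, and the change from nitro to a group of more heavy atoms does not cost activity. Diethylamino and methoxy cannot be told apart (a 1.7-fold lower number from compound 2 to compound 4 (0.22 log units; within the scatter)), which shows that two different groups joined to the ring through a heteroatom can sit level here, while propyl keeps a large lead over diethylamino (a 15-fold higher number from compound 1 to compound 4 (1.18 log units; beyond the scatter)), so the extra carbons of diethylamino do not reproduce what propyl gives. Nothing measured here explains why these four groups fall as they do.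

The compounds shown leave open whether a longer chain such as butyl, or a shorter one such as ethyl, would hold the number of compound 1, and whether the propyl result depends on an all-carbon chain. They also leave open how a smaller amine such as dimethylamino, or a carboxylic acid, would fall at this same carbon relative to diethylamino and nitro.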